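Swapping an Allyl Ether for a Bromobenzyl Ether

The source may hold more compounds than are shown below. What is called first, only, known or untested is meant among the compounds shown, and "the series" means these compounds.

Compound 1 `C=CCOc1cc(/C=C\c2cc(OC)c(OC)c(OC)c2)ccc1OC`: 12000 nM
Compound 2 `C/C=C/COc1cc(/C=C\c2cc(OC)c(OC)c(OC)c2)ccc1OC`: 5400 nM
Compound 3 `COc1ccc(/C=C\c2cc(OC)c(OC)c(OC)c2)cc1OCc1ccccc1`: 59000 nM

In a functional assay on MCF7 cells (Homo sapiens) for inhibition, read by MTT assay, with a stated time of 3 days (on this read-out higher numbers stand for weaker inhibition and lower numbers for stronger inhibition), compound 1 stands second highest of the three numbers: the step of a 2.2-fold lower number from compound 1 to compound 2 (0.35 log units; beyond the scatter) is a modest move downward, while the step of a 4.9-fold higher number from compound 1 to compound 3 (0.69 log units; beyond the scatter) is a modest move upward. Compound 4 `COc1ccc(/C=C\c2cc(OC)c(OC)c(OC)c2)cc1OCc1ccc(Br)cc1` differs from compound 1 by 4-bromophenyl in place of vinyl on a saturated chain carbon bound to an oxygen on an aromatic ring. The measured step that bears most directly on this is a 4.9-fold higher number from compound 1 to compound 3 (0.69 log units; beyond the scatter), a modest rise; the related step of an 11-fold higher number from compound 2 to compound 3 (1.04 log units; beyond the scatter) was large. For the measured compounds named here, no measured compound carries bromine, so the bromine's own share is unknown. A rise beyond the scatter in this assay is therefore expected for compound 4, roughly as large as the step to compound 3 or somewhat larger, giving an expected step of a 4.6-fold higher number from compound 1 to compound 4 (0.66 log units; beyond the scatter). The estimate for compound 4 is 55000 nM, with a range from 15000 nM to 200000 nM.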

Compound 4, half-maximal inhibitory concentration: 29000 nM
Compound 4: middle estimate off by 1.9-fold (0.28 log units), on the high side, and the stated range covers the measured number.
By their numbers in this assay, from the lowest: compound 2; then compound 1; then compound 4; then compound 3.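

In this assay the bromine's own share can now be read: bromo in place of hydrogen on an aromatic carbon gives a 2.0-fold lower number from compound 3 to compound 4 (0.31 log units; beyond the scatter) and so partly offsets the rise seen with the plain phenyl group. The recovery is incomplete, since 4-bromophenyl in place of vinyl still gives a 2.4-fold higher number from compound 1 to compound 4 (0.38 log units; beyond the scatter) and 4-bromophenyl in place of prop-1-en-1-yl gives a 5.4-fold higher number from compound 2 to compound 4 (0.73 log units; beyond the scatter) as well. Nothing available explains why the bromine lowers the number. Still open, going by these compounds, is how a 4-chlorophenyl group, an amine or a longer chain would behave on this saturated chain carbon.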